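Swapping the ethynyl arm for a methyl ester

A few compounds are considered here, and "the series" means these few. Any claim that something is new, unique, unknown or untested is made for them only; others in the source may bear on it.

Measured so far:
- compound 1, `CCc1ccnc(O[C@@H]2CC[C@@H](C)N(C(=O)c3ccccc3-n3nccn3)C2)c1`: 57 nM
- compound 2, `C#Cc1ccnc(O[C@@H]2CC[C@@H](C)N(C(=O)c3ccccc3-n3nccn3)C2)c1`: 49 nM

Both compounds were tested in an assay on CHO-K1 cells for displacement of a labelled ligand from Orexin/Hypocretin receptor type 1 (Homo sapiens), read by radioligand binding; a higher number here means a weaker inhibitor, a lower number a stronger inhibitor. Compound 1 gives 57 nM and compound 2 gives 49 nM. The step of a 1.2-fold lower number from compound 1 to compound 2 (0.07 log units; within the scatter) is the only one available, and it is small; compound 2 carries the lowest of the two numbers, but its gap to compound 1 lies within the scatter, so the two cannot be told apart.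

Compound 3, `COC(=O)c1ccnc(O[C@@H]2CC[C@@H](C)N(C(=O)c3ccccc3-n3nccn3)C2)c1`, is not yet measured. It differs from compound 2 by methoxycarbonyl in place of ethynyl on an aromatic carbon; the place is on an aromatic carbon of a six-membered aromatic ring with one nitrogen, meta to a large group and opposite the ring nitrogen. Within the data shown here, the one measured step exchanged two small carbon groups and barely moved the number, so it says little about a swap to a larger group carrying two oxygen atoms. With no closer guide, a modest weakening is expected for compound 3, a step of a 2.0-fold higher number from compound 2 to compound 3 (0.31 log units; beyond the scatter), giving an estimate of 100 nM with a range from 30 nM to 400 nM in this assay.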

Compound 3, inhibition constant: 310 nM
The estimate for compound 3 lay 3.1-fold (0.49 log units) below the measured number; low and high end bracket the measured number.
By their numbers in this assay, from the lowest: compounds 2 and 1 (each within the scatter of the next); then compound 3.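

In this assay, the place opposite the ring nitrogen proves sensitive to the group it carries. Ethyl and ethynyl could not be told apart there, but methoxycarbonyl stands clearly apart from both, with a 6.3-fold higher number from compound 2 to compound 3 (0.80 log units; beyond the scatter) and a 5.4-fold higher number from compound 1 to compound 3 (0.74 log units; beyond the scatter) as the two steps. Against ethynyl, the entering group brings 4 heavy atoms in place of 2, and 2 hydrogen-bond acceptors in place of 0, yet no measurement here shows which of these differences, if either, accounts for the higher number.

The compounds shown leave open whether the higher number follows the added size or the oxygen atoms, since methoxycarbonyl brings both at once. A propyl chain would add carbon atoms without oxygen, while a methoxy group, a carboxylic acid or a primary amide at this place would help show how far the trend with methoxycarbonyl depends on the ester itself.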